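Urea for amide on the pyrazole series: compound 4

The source may report more compounds than this note shows. Statements on the series, on what has been measured and on what is new or still open speak of the compounds shown alone.

Measured so far:
compound 1, `O=C(Nc1cccc(-n2cc(-c3ccncc3)c(-c3ccc(Cl)c(O)c3)n2)c1)Nc1ccc(Cl)c(Cl)c1` — 13900 nM
compound 2, `COc1cc(-c2nn(-c3cccc(NC(=O)c4cccc(C(F)(F)F)c4)c3)cc2-c2ccncc2)ccc1Cl` — 17600 nM
compound 3, `O=C(Nc1cccc(-n2cc(-c3ccncc3)c(-c3ccc(Cl)c(O)c3)n2)c1)Nc1cc(C(F)(F)F)cc(C(F)(F)F)c1` — 2410 nM

Three compounds on the shared core have numbers in a functional assay on HCC 2998 cells (Homo sapiens) for inhibition, read by sulforhodamine B assay, with a stated time of 48 h; a higher number here means a weaker inhibitor of growth, a lower number a stronger inhibitor of growth. Compound 2 holds the highest of the three; its nearest neighbour is compound 1, which lies within the scatter of it, while compound 3 stands well beyond the scatter on the lower side, so compound 3 is the only one of the three that is clearly apart from compound 2.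

The unmeasured compound 4, `COc1cc(-c2nn(-c3cccc(NC(=O)Nc4ccc(Cl)c(Cl)c4)c3)cc2-c2ccncc2)ccc1Cl`, is made from compound 2 by a single change: (3,4-dichlorophenyl)amino in place of 3-(trifluoromethyl)phenyl on a carbonyl carbon. Among the compounds with values here, the same carbamoyl arrangement with the same (3,4-dichlorophenyl)amino end is present in compound 1, which differs from compound 4 elsewhere, and for that pair no computed step is given; their two numbers simply stand side by side. Within the data shown here, compound 1 and compound 2 are within the scatter of each other, so the reading from compound 1 suggests no large step from the amide to the urea here.

For compound 4 the expected step of a 1.5-fold lower number from compound 2 to compound 4 (0.17 log units; within the scatter) is small, within the scatter, with a slight lean toward a lower number. The estimate for compound 4 is 12000 nM, with a range from 4000 nM to 35000 nM.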

Compound 4, concentration for total growth inhibition: 6200 nM
Estimate against measurement, compound 4: 1.9-fold (0.29 log units) above; the measured number falls inside the stated range.
By their numbers in this assay, from the lowest: compound 3; then compound 4; then compounds 1 and 2 (each within the scatter of the next).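

In this assay, within the data shown here, (3,4-dichlorophenyl)amino in place of 3-(trifluoromethyl)phenyl on a carbonyl carbon gives a 2.8-fold lower number from compound 2 to compound 4 (0.45 log units; beyond the scatter), a modest step and the first directly computed reading at this position, whereas the earlier compounds offered only side-by-side values for the amide and urea forms. With the (3,4-dichlorophenyl)carbamoyl end held constant, methyl in place of hydrogen on an oxygen on an aromatic ring gives a 2.2-fold lower number from compound 1 to compound 4 (0.35 log units; beyond the scatter), so this second place also moves the number by a modest step beyond the scatter. No measurement shown accounts for either step.

The first change replaces the link to the carbonyl and the ring substituents together, so the shown compounds do not separate the contribution of the added amide-type nitrogen from that of the two chlorines in place of trifluoromethyl. Also open, going by these compounds, is how the series would respond to an ethyl group in place of methyl on that oxygen, or to a carboxylic acid or an amine on the ring of the (3,4-dichlorophenyl)amino group.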